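Carboxy in Place of Methyl: Expecting Little Change

This account rests on a few compounds, and the source may have more. Where it says the series, first, only, none or still open, it means among the compounds named here.

Of the compounds shown here, three sharing one core have been tested in a functional assay on the whole organism (blood, strain albino) with Mus musculus as the target, with stated times of 6 days and 4 h, at a dose of 1 mmol/kg by the oral route; a lower number here means less inhibition, a higher number more inhibition at the dose given (going by the name of the read-out). Compound 1 `Cc1cc(C)n(-c2ccc(S(=O)(=O)N3CC(=O)N(C4CCCCC4)C3=S)cc2)n1` gives 2%, compound 2 `CCCCN1C(=O)CN(S(=O)(=O)c2ccc(-n3nc(C)cc3C)cc2)C1=S` gives 1%, and compound 3 `Cc1cc(C)n(-c2ccc(S(=O)(=O)N3CC(=O)N(c4ccccc4)C3=S)cc2)n1` gives 8%. Compound 2 holds the lowest of the three numbers, yet the steps of a number 1 percentage points lower from compound 1 to compound 2 (within the scatter) and a number 7 percentage points higher from compound 2 to compound 3 (within the scatter) lie within the scatter, as does a number 6 percentage points higher from compound 1 to compound 3 (within the scatter). Compound 4 `CCCCN1C(=O)CN(S(=O)(=O)c2ccc(-n3nc(C(=O)O)cc3C)cc2)C1=S` has not been measured; it differs from compound 2 by carboxy in place of methyl on an aromatic carbon. Within the data shown here, every measured step changes the group on the amide-type nitrogen in the ring and leaves the five-membered aromatic ring untouched, so no measured step bears on this change. With all three known values near zero, compound 4 is expected to stay in that region, a step of a number 2 percentage points higher from compound 2 to compound 4 (within the scatter) that means nothing beyond the scatter. The estimate for compound 4 is 3%, between -7% and 13%.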

Compound 4, a percentage reported as inhibition, in the whole organism at one dose (the size of the read-out at that dose, not a potency): 1%
The estimate for compound 4 lay 2 percentage points above the measured number, within the range that was stated.
By their numbers in this assay, from the lowest: compounds 2, 4, 1 and 3 (each within the scatter of the next).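

Among these compounds, this is the first reading at this aromatic carbon of the five-membered ring, since every earlier step left that ring untouched. In this assay, carboxy in place of methyl gives no change at the digits printed from compound 2 to compound 4 (within the scatter) and so shows no readable effect of going from 3,5-dimethyl-1H-pyrazol-1-yl to 3-carboxy-5-methyl-1H-pyrazol-1-yl on this core. No evidence at hand bears on this result.

With compound 2 already near zero, the step cannot tell whether carboxy would matter in a compound with a clearly higher number. On these data alone, whether an amine or a longer chain on this carbon would read differently remains open.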